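Amino for dimethylamino on a second core

The source may hold more compounds than are shown below. What is called first, only, known or untested is meant among the compounds shown, and "the series" means these compounds.

Compound 2 `COc1ccc(C(=O)c2ccc(OC)c3c2OC(C)(C)C=C3)c(NC(=O)CN(C)C)c1` and compound 1 `COc1ccc(C(=O)c2ccc(OC)c3c2OC(C)(C)C=C3)c(NC(=O)CN)c1` share one core and differ only by amino in place of dimethylamino on a saturated chain carbon bound to a carbonyl carbon. In a functional assay on A2780 cells (Homo sapiens) for antiproliferative activity, read by MTT assay, with a stated time of 48 h (a higher number here means a weaker inhibitor, a lower number a stronger inhibitor), compound 2 gives 790 nM, while compound 1 gives 380 nM, so that the change produced a 2.1-fold lower number from compound 2 to compound 1 (0.32 log units; beyond the scatter).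

Compound 3 `COc1ccc(C(=O)c2cc(OC)c(OC)c(OC)c2)c(NC(=O)CN(C)C)c1` carries the dimethylamino on a different core; the difference between the two cores is not broken down here. In this assay compound 3 gives 580 nM, a value within the scatter of compound 2 and of compound 1 alike.

Compound 4 `COc1ccc(C(=O)c2cc(OC)c(OC)c(OC)c2)c(NC(=O)CN)c1` has not yet been measured. It differs from compound 3 by amino in place of dimethylamino on a saturated chain carbon bound to a carbonyl carbon, the same change as that made between compound 2 and compound 1, at the same place. Going by the values given here, the step expected from this change in this assay is a 1.9-fold lower number from compound 3 to compound 4 (0.29 log units; within the scatter), and it rests on the single measured instance, a 2.1-fold lower number from compound 2 to compound 1 (0.32 log units; beyond the scatter). Among the compounds with values here, since only one example of the change is available, the expectation carries some uncertainty. In this assay compound 4 is therefore estimated at 300 nM, with a range from 150 nM to 600 nM.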

Compound 4, half-maximal inhibitory concentration: 190 nM
Estimate against measurement, compound 4: 1.6-fold (0.20 log units) above, and the stated range covers the measured number.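

In this assay, amino in place of dimethylamino gives a 3.1-fold lower number from compound 3 to compound 4 (0.48 log units; beyond the scatter), so the number falls on this core as it did on the core shared by compound 1 and compound 2. The change therefore carries from one core to the other in direction, and the two steps cannot be told apart in size: the same change on two cores in this assay, a 2.1-fold lower number (0.32 log units; beyond the scatter) from compound 2 to compound 1 and a 3.1-fold lower number (0.48 log units; beyond the scatter) from compound 3 to compound 4, 1.5-fold (0.17 log units) apart, within the scatter of two such steps. This rests on a single matched pair for each of two cores in one cell assay, so it does not show that the change would hold on any further core, nor does it explain why the amino compounds give the lower numbers.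

The compounds shown leave open whether methylamino would fall in line with amino and dimethylamino at this place, since only the unsubstituted and doubly methylated amines appear. They also leave open how a longer chain carrying the amino group, or a carboxylic acid in place of the amine, would behave on either core.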